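From Methyl to Pyridin-4-yl on the Shared Core

The compounds below may be only part of what the source reports. "The series", "measured", "known", "first", "only" and "open" are said of these compounds alone.

Of the compounds shown here, two sharing one core have been measured in an assay on microsomes from brain for inhibition of Fatty-acid amide hydrolase 1 (Rattus norvegicus), read by fluorescence and HPLC, with a stated time of 60 min; a lower number here means a stronger inhibitor, a higher number a weaker inhibitor. Compound 1 `CCCCCCCCc1ccc(OCC(=O)Cn2nnc(C)n2)cc1` gives 27 nM in this assay. Compound 2 `CCCCCCCCc1ccc(OCC(=O)Cn2nnc(-c3ccccc3)n2)cc1` carries a phenyl where compound 1 carries a methyl. In this assay compound 2 gives 24 nM. Compound 1 stands highest of these two numbers, yet the step of a 1.1-fold lower number from compound 1 to compound 2 (0.05 log units; within the scatter) lies within the scatter, so the two compounds cannot be told apart on these numbers.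

Compound 3 `CCCCCCCCc1ccc(OCC(=O)Cn2nnc(-c3ccncc3)n2)cc1` has not yet been measured. It differs from compound 1 as follows: pyridin-4-yl in place of methyl on an aromatic carbon. Among the compounds with values here, only one measured step bears on this change, and it replaced the same methyl with a phenyl, another six-membered aromatic ring: a 1.1-fold lower number from compound 1 to compound 2 (0.05 log units; within the scatter). Since that ring left the number essentially unchanged, the expected step is a 1.1-fold lower number from compound 1 to compound 3 (0.03 log units; within the scatter), that is, nothing beyond the scatter in either direction. Compound 3 is therefore estimated at 25 nM in this assay, with a range from 10 nM to 60 nM.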

Compound 3, half-maximal inhibitory concentration: 24 nM
The estimate for compound 3 lay 1.0-fold (0.02 log units) above the measured number; low and high end bracket the measured number.
By their numbers in this assay, from the lowest: compounds 2, 3 and 1 (each within the scatter of the next).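

Compound 3 brings a ring nitrogen and a hydrogen-bond acceptor to this aromatic carbon, yet in this assay replacing the phenyl of compound 2 with pyridin-4-yl gives no change at the digits printed from compound 2 to compound 3 (within the scatter). Replacing the methyl of compound 1 with the same ring gives a 1.1-fold lower number from compound 1 to compound 3 (0.05 log units; within the scatter), so a six-membered aromatic ring with a hetero atom, like the all-carbon phenyl ring, cannot be told apart from methyl at this position. Nothing at hand explains why these three groups give numbers so close together.

The compounds shown leave open whether the number would stay this close with a carboxylic acid or an amine on this aromatic carbon, or with a bare hydrogen in place of methyl. They also leave open how much the rest of the shared core matters, for example whether an alcohol in place of the carbonyl, or a shorter chain on the far ring, would move the number beyond the scatter.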